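The source may hold more compounds than are shown below. What is called first, only, known or untested is meant among the compounds shown, and "the series" means these compounds.

Measured compounds in a functional assay on BXPC-3 cells (Homo sapiens) for cytotoxicity, read by MTT assay, with a stated time of 72 h; on this read-out lower numbers stand for stronger inhibition and higher numbers for weaker inhibition:
compound 1 `O=C1C(Nc2ccc(-c3ccccc3)cc2)=CC(=O)c2ncncc21`: 500 nM
compound 2 `COc1ccc(-c2ccc(NC3=CC(=O)c4ncncc4C3=O)cc2)cc1`: 3500 nM
compound 3 `COc1ccc(NC2=CC(=O)c3ncncc3C2=O)cc1`: 1700 nM

Compound 3 stands second highest of the three numbers in this assay; the nearest is compound 2, and the furthest is compound 1. The step that led to compound 3 from compound 1 was a 3.4-fold higher number from compound 1 to compound 3 (0.53 log units; beyond the scatter), while a 7.0-fold higher number from compound 1 to compound 2 (0.85 log units; beyond the scatter) and a 2.1-fold lower number from compound 2 to compound 3 (0.31 log units; beyond the scatter) complete the small picture.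

Compound 4 `CCOC(=O)c1ccc(NC2=CC(=O)c3ncncc3C2=O)cc1` differs from compound 3 by ethoxycarbonyl in place of methoxy on an aromatic carbon. Among the measured compounds shown here, no measured pair involves an ethoxycarbonyl group, so the measured steps bear on it only loosely: they show that changes at this aromatic carbon have moved this assay by modest amounts in both directions, and nothing more specific. An expectation for compound 4 must therefore stay close to compound 3, with a wide range, and the step is estimated as a 1.2-fold higher number from compound 3 to compound 4 (0.07 log units; within the scatter). Compound 4 is expected to give about 2000 nM in this assay, within a range from 600 nM to 7000 nM.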

Compound 4, half-maximal inhibitory concentration: 5900 nM
Compound 4: middle estimate off by 3.0-fold (0.47 log units), on the low side, and the stated range covers the measured number.
By their numbers in this assay, from the lowest: compound 1; then compound 3; then compounds 2 and 4 (each within the scatter of the next).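

In this assay, among the compounds shown here, the ethoxycarbonyl group, the first group at this aromatic carbon that is neither methoxy nor an aryl group, gives a 3.5-fold higher number from compound 3 to compound 4 (0.54 log units; beyond the scatter) and so takes the number further from compound 1 than methoxy does. Against the 4-methoxyphenyl group it gives a 1.7-fold higher number from compound 2 to compound 4 (0.23 log units; within the scatter) and thus stands level with it, while the step from the phenyl group, a 12-fold higher number from compound 1 to compound 4 (1.07 log units; beyond the scatter), is the only large one in the set and leaves compound 1 with the lowest number of the four. No measurement at hand accounts for these differences.

Going by these compounds, what a carboxylic acid, an amine or a longer chain would give at this carbon remains open. So does whether any other group here would match the phenyl group of compound 1.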